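From thiophen-3-yl to 4-chlorophenyl: tolerance in HeLa cells

A few compounds are considered here, and "the series" means these few. Any claim that something is new, unique, unknown or untested is made for them only; others in the source may bear on it.

Measured so far:
Compound 1, `COc1nc(-c2ccsc2)ccc1[C@@H](c1ccccc1)[C@@](O)(CCN(C)C)c1cccc2ccccc12`, gives in a toxicity assay on HeLa cells (Homo sapiens) for cytotoxicity (a lower number here means that less compound is tolerated, a higher number that more compound is tolerated), only a limit: > 64 ug/mL.
Compound 2, `COc1nc(-c2ccc(OC(F)(F)F)cc2)ccc1[C@@H](c1ccccc1)[C@@](O)(CCN(C)C)c1cccc2ccccc12`, gives in this assay only a limit: > 64 ug/mL.

Compound 1 therefore stands at a limit of this assay rather than at a measured number. Within the data shown here, the one measured step, a step that the two limits leave unreadable from compound 1 to compound 2, could not be sized, as both of its ends sit at the limit of > 64 ug/mL in this assay, at which 2 of the 2 values shown sit. The change to the unmeasured compound 3, `COc1nc(-c2ccc(Cl)cc2)ccc1[C@@H](c1ccccc1)[C@@](O)(CCN(C)C)c1cccc2ccccc12`, is 4-chlorophenyl in place of thiophen-3-yl on an aromatic carbon. Among the measured compounds shown here, the step from compound 1 to compound 2 is the only measured step that bears on it, since it too exchanges the thiophen-3-yl for a substituted phenyl ring, and it showed no readable step. In this assay, then, compound 3 is expected to show no step beyond the scatter, so a step that the limit leaves unreadable from compound 1 to compound 3 is expected to be flat. Compound 3 is estimated at 80 ug/mL, within 40 ug/mL to 160 ug/mL, and most likely again reported only as a limit.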

Compound 3, half-maximal cytotoxic concentration: > 64 ug/mL
Compound 3: only a limit was reported; the forecaster's own chance of this, stated with the estimate: 85%; the middle value lies beyond the limit too.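

Compound 3 gives only a limit in this assay, so no step can be read between it and compound 1 or compound 2, which also give only limits: the limit of > 64 ug/mL in this assay, at which 3 of the 3 values shown sit.

The compounds shown leave open how much of each compound the cells tolerate, and whether the three ring groups differ at all.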